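The source may report more compounds than this note shows. Statements on the series, on what has been measured and on what is new or still open speak of the compounds shown alone.

Compound 2 `COc1cc2cc(Oc3ccc(NC(=O)Nc4ccc(Cl)c(C(F)(F)F)c4)cc3)c(C)nc2cc1OC` gives 4590 nM in a functional assay on BT-549 cells (Homo sapiens) for inhibition, read by sulforhodamine B assay, with a stated time of 48 h; on this read-out higher numbers stand for weaker inhibition of growth and lower numbers for stronger inhibition of growth; compound 1 `COc1cc2cc(Oc3ccc(NC(=O)Nc4cccc(C(F)(F)F)c4)cc3)c(C)nc2cc1OC` gives 6180 nM in this assay, and the two sit within the scatter of each other, as a 1.3-fold lower number from compound 1 to compound 2 (0.13 log units; within the scatter) shows. Compound 3 `COc1cc2cc(Oc3ccc(NC(=O)Nc4ccc(Cl)c(Cl)c4)cc3)c(C)nc2cc1OC` carries chloro in place of trifluoromethyl on an aromatic carbon. For the measured compounds named here, no measured step exchanges a trifluoromethyl group for chloro; the only step in hand, a 1.3-fold lower number from compound 1 to compound 2 (0.13 log units; within the scatter), concerns a different change and itself lies within the scatter. The expected step is therefore a 1.0-fold lower number from compound 2 to compound 3 (0.01 log units; within the scatter), within the scatter. Compound 3 is estimated at 4500 nM, with a range from 2000 nM to 10000 nM.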

Compound 3, concentration for total growth inhibition: 11700 nM
Compound 3: the middle estimate sits 2.6-fold (0.41 log units) below what was measured; the measured number lies above the stated range.
By their numbers in this assay, from the lowest: compounds 2, 1 and 3 (each within the scatter of the next, the first and the last beyond it).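

At this position, ortho to a chloro group and meta to a large group, trifluoromethyl and chloro are not interchangeable in this assay, since the exchange gives a 2.5-fold higher number from compound 2 to compound 3 (0.41 log units; beyond the scatter) and so weaker inhibition of growth. For the compounds shown here, this is the first step to pass the scatter, whereas a 1.9-fold higher number from compound 1 to compound 3 (0.28 log units; within the scatter) does not separate 3,4-dichlorophenyl from 3-(trifluoromethyl)phenyl. No available data bear on the origin of the step.

From the compounds shown here alone, it remains open whether a methoxy group, a nitrile or an amine at this position would match trifluoromethyl. Whether the step carries over to other cell lines is also unresolved.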